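The source may report more compounds than this note shows. Statements on the series, on what has been measured and on what is new or still open speak of the compounds shown alone.

Compound 2 `COC(=O)[C@@]1(C)CCC=C2[C@@H]1CC[C@@H](C)[C@]2(C)Cc1c(C)[nH]c2ccc(Cl)cc12` stands level with compound 1 `COC(=O)[C@@]1(C)CCC=C2[C@@H]1CC[C@@H](C)[C@]2(C)Cc1c(C)[nH]c2ccccc12` on the single measure available: in a functional assay on SW1573 cells (Homo sapiens) for inhibition, read by sulforhodamine B assay, with a stated time of 48 h (a lower number here means a stronger inhibitor of growth, a higher number a weaker inhibitor of growth), compound 2 gives 14000 nM, and in this assay compound 1 gives 14000 nM. Within the data shown here, the one measured step, no change at the digits printed from compound 1 to compound 2 (within the scatter), stays within the scatter of the assay, so placing chloro on that aromatic carbon of the shared core made no difference that could be read.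

Compound 3 `COC(=O)[C@@]1(C)CCC=C2[C@@H]1CC[C@@H](C)[C@]2(C)Cc1c(C)[nH]c2ccc(F)cc12` differs from compound 2 by fluoro in place of chloro on an aromatic carbon. Among the measured compounds shown here, no measured step involves fluoro, so the only guide is the chloro step, which showed nothing beyond the scatter. One halogen giving way to another at the same aromatic carbon therefore offers no reason to expect a step in this assay beyond the scatter, in either direction. For compound 3 the expected step is no change at the digits printed from compound 2 to compound 3 (within the scatter). Compound 3 is thus estimated to give 14000 nM in this assay, within a range from 7000 nM to 28000 nM.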

Compound 3, concentration for 50% growth inhibition: 12000 nM
Compound 3: middle estimate off by 1.2-fold (0.07 log units), on the high side, and the stated range covers the measured number.
By their numbers in this assay, from the lowest: compounds 3, 1 and 2 (each within the scatter of the next).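

In this assay the exchange of chloro for fluoro gives a 1.2-fold lower number from compound 2 to compound 3 (0.07 log units; within the scatter) and fluoro in place of hydrogen gives a 1.2-fold lower number from compound 1 to compound 3 (0.07 log units; within the scatter) so both steps lie within the scatter. The earlier compounds shown here showed this only for chloro against hydrogen, whereas a second halogen now gives the same reading. Hydrogen, chloro and fluoro on this aromatic carbon therefore cannot be told apart in this measure, and no order can be drawn among compounds 1, 2 and 3.

As far as these compounds go, whether an amine, a methoxy group or a carboxylic acid on this carbon would also leave the number in place remains open, as does whether replacing the methyl ester elsewhere on the shared core would move it. Nothing available here bears on why these three compounds read alike.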